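The source may report more compounds than this note shows. Statements on the series, on what has been measured and on what is new or still open speak of the compounds shown alone.

In an assay on HL-60 cells for agonist activity at vitamin D3 receptor (Homo sapiens), with a stated time of 96 h (a higher number here means that more compound is needed for the effect, a lower number that less compound is needed), compound 3 `CCn1c(C(=O)N[C@H](CO)CCO)ccc1C(CC)(CC)c1ccc(OCC(O)C(C)(C)C)c(C)c1` gives 110 nM, the second highest of the three numbers. Compound 1 `CCn1c(C(=O)NCCO)ccc1C(CC)(CC)c1ccc(OCC(O)C(C)(C)C)c(C)c1` gives 5640 nM, and compound 2 `CCn1c(C(=O)N[C@@H](C)CO)ccc1C(CC)(CC)c1ccc(OCC(O)C(C)(C)C)c(C)c1` gives 1.06 nM. Within the data shown here, the steps that bear on the next change are a 51-fold lower number from compound 1 to compound 3 (1.71 log units; beyond the scatter), a 100-fold higher number from compound 2 to compound 3 (2.02 log units; beyond the scatter) and a 5300-fold lower number from compound 1 to compound 2 (3.73 log units; beyond the scatter). Compound 4 `CCn1c(C(=O)NCCC(=O)O)ccc1C(CC)(CC)c1ccc(OCC(O)C(C)(C)C)c(C)c1` carries 2-carboxyethyl in place of 3-hydroxy-1-(hydroxymethyl)propyl on an amide-type nitrogen. Among the measured compounds shown here, its chain is unbranched at the carbon bound to the amide nitrogen, as in compound 1, and branching at that carbon gave the large gains seen in a 5300-fold lower number from compound 1 to compound 2 (3.73 log units; beyond the scatter) and a 51-fold lower number from compound 1 to compound 3 (1.71 log units; beyond the scatter); no measured compound carries a carboxylic acid, so that part is untested. A step back toward compound 1 is therefore expected, an 18-fold higher number from compound 3 to compound 4 (1.26 log units; beyond the scatter), its size uncertain. Compound 4 is estimated at 2000 nM, range 300 nM to 15000 nM.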

Compound 4, half-maximal effective concentration: 33200 nM
Compound 4: middle estimate off by 17-fold (1.22 log units), on the low side; measured number above the stated range.
By their numbers in this assay, from the lowest: compound 2; then compound 3; then compound 1; then compound 4.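

On the amide-type nitrogen, 2-carboxyethyl gives the highest number of the series in this assay, and carboxy in place of hydroxy on the unbranched chain still costs something, with a 5.9-fold higher number from compound 1 to compound 4 (0.77 log units; beyond the scatter) as the step. Against the branched chains the loss is far larger, with a 300-fold higher number from compound 3 to compound 4 (2.48 log units; beyond the scatter) and a 31000-fold higher number from compound 2 to compound 4 (4.50 log units; beyond the scatter) as the steps. Nothing measured here accounts for these steps.

Open, from the compounds shown here alone, is whether a carboxylic acid on a chain branched with methyl, as in compound 2, would retain the low number of compound 2. An amine or a primary amide at the chain end also remains to be placed against the hydroxy and carboxy groups.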